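This account rests on a few compounds, and the source may have more. Where it says the series, first, only, none or still open, it means among the compounds named here.

Compound 1 `O=C(Nc1ccc(Cl)c(-c2nnc3c(Cl)cccn23)c1)c1cccnc1` is a benzamide-type compound built on a shared core with a (pyridin-3-yl)carbonyl attached to the amide nitrogen. In a functional assay on A549 cells (Homo sapiens) for antiproliferative activity, read by MTT assay, with a stated time of 72 h (a lower number here means a stronger inhibitor, a higher number a weaker inhibitor), compound 1 reaches only the limit of the measurement, > 100000 nM, so no number is known for it. Compound 2 `CS(=O)(=O)c1ccc(C(=O)Nc2ccc(Cl)c(-c3nnc4c(Cl)cccn34)c2)c(Cl)c1` also sits at a limit in this assay, > 100000 nM. Two of the three measured values therefore stand at the limit of > 100000 nM in this assay, at which 2 of the 3 values shown sit. For the measured compounds named here, compound 3 `O=C(Nc1ccc(Cl)c(-c2nnc3c(Cl)cccn23)c1)c1c(F)cccc1Cl` is the only one with a number, giving 72300 nM in this assay, and the step of an at least 1.3-fold lower number from compound 1 to compound 3 (0.14 log units; that floor lies within the scatter) remains within the usual scatter.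

Compound 4 `O=C(Nc1ccc(Cl)c(-c2nnc3c(Cl)cccn23)c1)c1ccccc1` differs from compound 1 by phenyl in place of pyridin-3-yl on a carbonyl carbon. Going by the values given here, the only measured step that touches the same carbonyl carbon is the one from compound 1 to compound 3, and that step stayed within the scatter. The expectation for compound 4 is therefore no step beyond the scatter, with the step of a number no higher from compound 1 to compound 4 (the limit leaves the size open) estimated as essentially flat. Compound 4 is estimated at 100000 nM in this assay, within a range of 40000 nM to 300000 nM, most likely again reported only as a limit.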

Compound 4, half-maximal inhibitory concentration: 76900 nM
For compound 4 the middle estimate is 1.3-fold (0.11 log units) above the measured one, and the stated range covers the measured number.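

In this assay compound 4 gives a second number for this place on the carbonyl carbon, so two aromatic groups can now be compared directly. Plain phenyl and 2-chloro-6-fluorophenyl cannot be told apart (a 1.1-fold higher number from compound 3 to compound 4 (0.03 log units; within the scatter)), so the chlorine and fluorine of that group bring no change beyond the scatter. Phenyl in place of pyridin-3-yl reads as an at least 1.3-fold lower number from compound 1 to compound 4 (0.11 log units; that floor lies within the scatter), and the true size of this step stays unknown because its starting value is only a limit: the limit of > 100000 nM in this assay, at which 2 of the 4 values shown sit.

The compounds shown leave open whether an amine or a carboxylic acid on the phenyl ring would move the number beyond the scatter. They also leave open what a cyclohexyl group on the same carbonyl carbon would do.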